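Removing the Nitro Group from an Aryl Sulfonamide Inhibitor

The source may report more compounds than this note shows. Statements on the series, on what has been measured and on what is new or still open speak of the compounds shown alone.

Compound 1 `COc1ccc(S(=O)(=O)N2CCc3cccc(-c4ccc([N+](=O)[O-])cc4)c32)cc1` gives 52.5 nM in a functional assay on KB cells (Homo sapiens) for inhibition, with a stated time of 72 h (a lower number here means a stronger inhibitor, a higher number a weaker inhibitor), the higher of the two numbers shown, although the gap to compound 2 `COc1ccc(S(=O)(=O)N2CCc3cccc(-c4ccc(F)c(F)c4)c32)cc1` at 45 nM lies within the scatter. Compound 3 `COc1ccc(S(=O)(=O)N2CCc3cccc(-c4ccccc4)c32)cc1` differs from compound 1 by hydrogen in place of nitro on an aromatic carbon. Within the data shown here, the one measured step, a 1.2-fold lower number from compound 1 to compound 2 (0.07 log units; within the scatter), exchanges the whole 4-nitrophenyl group and hardly moves the number, so a smaller change at the same group is expected to stay within the scatter as well. Compound 3 is therefore expected near 55 nM, between 25 nM and 120 nM, a step of a 1.0-fold higher number from compound 1 to compound 3 (0.02 log units; within the scatter).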

Compound 3, half-maximal inhibitory concentration: 120 nM
Compound 3: middle estimate off by 2.2-fold (0.34 log units), on the low side; low and high end bracket the measured number.
By their numbers in this assay, from the lowest: compounds 2 and 1 (each within the scatter of the next); then compound 3.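

Among these compounds, the plain phenyl group is the first change here to move the number beyond the scatter: in this assay the steps read a 2.3-fold higher number from compound 1 to compound 3 (0.36 log units; beyond the scatter) and a 2.7-fold higher number from compound 2 to compound 3 (0.43 log units; beyond the scatter) for the loss of the ring's substituents. So a nitro group or two fluorines on this ring each give a lower number than bare phenyl, although those two compounds lie within the scatter of each other. Nothing available explains this difference. As far as these compounds go, whether an amine, a carboxylic acid or a single fluorine on this ring would also keep the number low stays open.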